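Replacing a Biaryl Tail with a Small Aminophenyl Group

The source may report more compounds than this note shows. Statements on the series, on what has been measured and on what is new or still open speak of the compounds shown alone.

Of the compounds shown here, three sharing one core have been measured. Compound 1 `NC1CCC(Nc2nc(NCc3ccc(-c4cccc(F)c4)cc3)c3ncn(C4CCCC4)c3n2)CC1` gives 211 nM in a functional assay on HOS cells (Homo sapiens) for inhibition, with a stated time of 72 h; a higher number here means a weaker inhibitor, a lower number a stronger inhibitor. Compound 2 `NC1CCC(Nc2nc(NCc3ccc(-c4ccco4)cc3)c3ncn(C4CCCC4)c3n2)CC1` gives 102 nM, and compound 3 `NC1CCC(Nc2nc(NCc3ccc(-n4cccn4)cc3)c3ncn(C4CCCC4)c3n2)CC1` gives 103 nM. Among these three numbers compound 3 stands second highest: its nearest neighbour is compound 2, whose number is a 1.0-fold higher number from compound 2 to compound 3 (0.00 log units; within the scatter), while compound 1 is furthest, with a 2.0-fold lower number from compound 1 to compound 3 (0.31 log units; beyond the scatter). The other measured step, a 2.1-fold lower number from compound 1 to compound 2 (0.32 log units; beyond the scatter), is of similar modest size.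

Compound 4 `Nc1ccccc1CNc1nc(NC2CCC(N)CC2)nc2c1ncn2C1CCCC1` has not yet been measured. Its difference from compound 3 is 2-aminophenyl in place of 4-(1H-pyrazol-1-yl)phenyl on a saturated chain carbon bound to a nitrogen on an aromatic ring. None of the three measured steps involves this kind of change: all of them only swapped the group on an aromatic carbon of the same phenyl ring, and each shifted the number by a modest amount or not at all. There is therefore no direct guide, and a larger move in either direction cannot be excluded.

Compound 4 is expected to give 250 nM, with a plausible range from 70 nM to 900 nM. This estimate means an expected step of a 2.4-fold higher number from compound 3 to compound 4 (0.39 log units; beyond the scatter).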

Compound 4, half-maximal inhibitory concentration: 2030 nM
Compound 4: the middle estimate sits 8.1-fold (0.91 log units) below what was measured, and the stated range ends below it.
By their numbers in this assay, from the lowest: compounds 2 and 3 (each within the scatter of the next); then compound 1; then compound 4.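

Changing the whole group on the saturated chain carbon matters far more than changing the outer ring alone: the step is a 20-fold higher number from compound 3 to compound 4 (1.29 log units; beyond the scatter), and a 20-fold higher number from compound 2 to compound 4 (1.30 log units; beyond the scatter). Among the earlier compounds, swapping only the outer ring gave no more than a 2.1-fold lower number from compound 1 to compound 2 (0.32 log units; beyond the scatter), so this position tolerates different outer rings but not this smaller 2-aminophenyl group, at least among the compounds shown. No measurement is available that explains the loss of potency.

This single change removes the outer ring and adds an amine on the remaining ring, and these compounds cannot show which of the two drives the step. A plain phenyl group at this place would help separate the two, as would a methyl group in place of the amine.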